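This account rests on a few compounds, and the source may have more. Where it says the series, first, only, none or still open, it means among the compounds named here.

Measured so far:
- Compound 1 `COc1cc2c(cc1O)[C@@H]1CCc3cc(OC)c(OC)c(OC)c3[C@H]2CN1S(=O)(=O)c1ccc(C)cc1`: 10800 nM
- Compound 2 `COc1cc2c(cc1O)[C@@H]1CCc3cc(OC)c(OC)c(OC)c3[C@H]2CN1C(=O)C(F)(F)F`: 27800 nM

In a functional assay on HT-29 cells (Homo sapiens) for cytotoxicity, read by MTT assay, with a stated time of 96 h (a lower number here means a stronger inhibitor, a higher number a weaker inhibitor), compound 2 gives 27800 nM, the higher of the two numbers, which makes it the weaker inhibitor of the pair. Compound 3 `COc1cc2c(cc1OC(C)=O)[C@@H]1CCc3cc(OC)c(OC)c(OC)c3[C@H]2CN1C(=O)C(F)(F)F` is made from compound 2 by one change: acetyl in place of hydrogen on an oxygen on an aromatic ring. In words, acetyl takes the place of hydrogen on an oxygen on an aromatic ring, turning hydroxy to acetoxy.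

Among the measured compounds shown here, only one measured step exists, a 2.6-fold higher number from compound 1 to compound 2 (0.41 log units; beyond the scatter). It was modest and replaced a group on an amine nitrogen in a ring, so it says nothing direct about this oxygen. For the measured compounds named here, no measured step tests the new change, so no step beyond the scatter is expected, and the range is kept wide. The expected step is a 1.2-fold lower number from compound 2 to compound 3 (0.06 log units; within the scatter). For compound 3 the estimated value is 24000 nM, with an expected range of 9000 nM to 60000 nM.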

Compound 3, half-maximal inhibitory concentration: 40800 nM
Compound 3: the middle estimate sits 1.7-fold (0.23 log units) below what was measured; the range from low to high includes it.
By their numbers in this assay, from the lowest: compound 1; then compounds 2 and 3 (each within the scatter of the next).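

In this assay, among the compounds shown here, this is the first look at the oxygen on the aromatic ring: turning hydroxy to acetoxy gives a 1.5-fold higher number from compound 2 to compound 3 (0.17 log units; within the scatter), so compound 2 and compound 3 cannot be told apart. With trifluoromethylcarbonyl on the ring nitrogen, then, a free hydroxy at this place is not needed to keep the number within the scatter, and the added acetyl is tolerated in this read-out. Nothing available here gives a reason for this result.

Still open, on these data alone, is whether this tolerance extends to other groups on the same oxygen, such as a longer chain, a benzoyl group or a chain carrying an amine. As far as these compounds go, it is also open whether acetoxy would read the same with the (4-methylphenyl)sulfonyl group of compound 1 on the nitrogen.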